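The source may hold more compounds than are shown below. What is called first, only, known or untested is meant among the compounds shown, and "the series" means these compounds.

Measured so far:
Compound 1, `CCOC(=O)c1c(-c2cc3ccccc3oc2=O)nn(-c2ccccc2)c1C(=O)OCC`, in a functional assay on A549 cells (Homo sapiens) for cytotoxicity, read by MTT assay, with a stated time of 48 h (a higher number here means a weaker inhibitor, a lower number a stronger inhibitor), gives 100000 nM.
Compound 2, `CCOC(=O)c1c(-c2cc3ccc(OC)cc3oc2=O)nn(-c2ccccc2)c1C(=O)OCC`, in this assay gives 132000 nM.

Both numbers are very weak, and the one measured step, a 1.3-fold higher number from compound 1 to compound 2 (0.12 log units; within the scatter), lies within the scatter; on the numbers shown, compound 2 stands level with compound 1 rather than apart from it. Compound 3, `CCOC(=O)c1c(-c2cc3ccc(OCC=C(C)C)cc3oc2=O)nn(-c2ccccc2)c1C(=O)OCC`, differs from compound 2 by 2-methylprop-1-en-1-yl in place of hydrogen on a saturated chain carbon bound to an oxygen on an aromatic ring, so the methoxy of compound 2 becomes a (3-methylbut-2-en-1-yl)oxy chain. Going by the values given here, the only step that bears on this place is a 1.3-fold higher number from compound 1 to compound 2 (0.12 log units; within the scatter), which put the methoxy in and changed nothing beyond the scatter. Among the compounds with values here, no measured step shows what a longer chain at this oxygen does. The expectation is therefore a step of a 1.7-fold lower number from compound 2 to compound 3 (0.22 log units; within the scatter), no change beyond the scatter. For compound 3 the estimate in this assay is 80000 nM, within 30000 nM to 200000 nM.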

Compound 3, half-maximal inhibitory concentration: 136000 nM
The estimate for compound 3 lay 1.7-fold (0.23 log units) below the measured number; measured number inside the range.
By their numbers in this assay, from the lowest: compounds 1, 2 and 3 (each within the scatter of the next).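

In this assay, going by these compounds alone, a longer chain on this oxygen, (3-methylbut-2-en-1-yl)oxy in place of methoxy, gives a 1.0-fold higher number from compound 2 to compound 3 (0.01 log units; within the scatter), the first measured look at chain length here. Set against hydrogen on the aromatic carbon, the same chain gives a 1.4-fold higher number from compound 1 to compound 3 (0.13 log units; within the scatter), so hydrogen, methoxy and this chain all stand level at this position, and every number remains very weak. No evidence at hand speaks to the reason for this flat result.

Still open, from the compounds shown here alone, is whether a different kind of group on this oxygen, such as a chain ending in an amine or a carboxylic acid, would move the number beyond the scatter. Also open, going by these compounds, is whether changes at other places on the shared core would lift these compounds out of this very weak range.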